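The source may report more compounds than this note shows. Statements on the series, on what has been measured and on what is new or still open speak of the compounds shown alone.

Compound 3 `COc1cc(C(F)(F)F)cc(SC)c1C(=O)NC1(c2ccc(C)cc2)CCCN(C)C1` gives the highest number of the three measured compounds in an assay on cells for inhibition of sodium- and chloride-dependent glycine transporter 1 (Homo sapiens) (on this read-out lower numbers stand for an effect already at smaller amounts and higher numbers for an effect only at larger amounts of compound), at 230 nM. Compound 1 `COc1cc(C(F)(F)F)cc(SC)c1C(=O)NC1(c2ccc(F)cc2)CCCN(C)C1` gives 26 nM and compound 2 `COc1cc(C(F)(F)F)cc(SC)c1C(=O)NC1(c2ccc(Cl)cc2)CCCN(C)C1` gives 28 nM; the step of a 1.1-fold higher number from compound 1 to compound 2 (0.03 log units; within the scatter) lies within the scatter. The steps of an 8.8-fold higher number from compound 1 to compound 3 (0.95 log units; beyond the scatter) and an 8.2-fold higher number from compound 2 to compound 3 (0.91 log units; beyond the scatter) show that a methyl at this position gives a weaker effect than either halogen. Compound 4 `COc1ccc(C2(NC(=O)c3c(OC)cc(C(F)(F)F)cc3SC)CCCN(C)C2)cc1` differs from compound 3 by methoxy in place of methyl on an aromatic carbon. Going by the values given here, no measured step exchanges methyl for methoxy, so the only guide is that replacements at this position have shifted the number by modest amounts. For compound 4 the expected step is a 1.9-fold lower number from compound 3 to compound 4 (0.28 log units; within the scatter), towards a lower number, held loosely. The estimate for compound 4 is 120 nM, with a range from 35 nM to 500 nM.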

Compound 4, half-maximal effective concentration: 170 nM
The estimate for compound 4 lay 1.4-fold (0.15 log units) below the measured number; the measured number falls inside the stated range.
By their numbers in this assay, from the lowest: compounds 1 and 2 (each within the scatter of the next); then compounds 4 and 3 (each within the scatter of the next).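

Methoxy and methyl cannot be told apart at this position: a 1.4-fold lower number from compound 3 to compound 4 (0.13 log units; within the scatter) stays small, so the added oxygen of methoxy does not bring the number down to the level of the halogens. The halogens remain clearly separate, with a 6.1-fold higher number from compound 2 to compound 4 (0.78 log units; beyond the scatter) and a 6.5-fold higher number from compound 1 to compound 4 (0.82 log units; beyond the scatter), so the four compounds fall into two groups, chloro and fluoro at the low numbers and methyl and methoxy at the higher ones. Nothing available explains this split. Going by these compounds, whether a nitrile, an amine or a carboxylic acid here would sit with the halogens or with the other pair remains open.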